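The source may hold more compounds than are shown below. What is called first, only, known or untested is meant among the compounds shown, and "the series" means these compounds.

Compound 1 `CC(=O)OC[C@H]1O[C@@H](n2cc(-c3cc(-c4ccc(C(C)(C)C)cc4)no3)c(=O)[nH]c2=O)C[C@@H]1OC(C)=O` and compound 2 `CCc1ccc(-c2cc(-c3cn([C@H]4C[C@H](OC(C)=O)[C@@H](COC(C)=O)O4)c(=O)[nH]c3=O)on2)cc1` share one core. Among the measured compounds shown here, in a functional assay on NUGC-3 cells (Homo sapiens) for cytotoxicity, read by sulforhodamine B assay, tested at 10 uM (a lower number here means less inhibition, a higher number more inhibition at the concentration tested (going by the name of the read-out)), compound 1 gives 32.8%, while compound 2 gives 72.6%, the higher of the two numbers measured so far, after a large step of a number 39.8 percentage points higher from compound 1 to compound 2 (beyond the scatter). Compound 3 `CCCCc1ccc(-c2cc(-c3cn([C@H]4C[C@H](OC(C)=O)[C@@H](COC(C)=O)O4)c(=O)[nH]c3=O)on2)cc1` differs from compound 2 by ethyl in place of hydrogen on a saturated chain carbon, two bonds along the chain from an aromatic carbon. For the measured compounds named here, only that one measured step bears on this change, and it was large, so a sizeable move in either direction is possible. A modest fall is expected, with a number 12.6 percentage points lower from compound 2 to compound 3 (beyond the scatter). For compound 3 the estimate is 60%, within a range from 35% to 85%.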

Compound 3, a percentage reported as inhibition, at one concentration (the size of the read-out at that concentration, not a potency): 39.8%
Compound 3: the middle estimate sits 20.2 percentage points above what was measured; the measured number falls inside the stated range.
By their numbers in this assay, from the lowest: compounds 1 and 3 (each within the scatter of the next); then compound 2.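

In this assay, going from 4-ethylphenyl to 4-butylphenyl gives a number 32.8 percentage points lower from compound 2 to compound 3 (beyond the scatter), so extending this chain by ethyl does not preserve the high number of compound 2. Butyl in place of tert-butyl gives a number 7 percentage points higher from compound 1 to compound 3 (within the scatter), so these two groups cannot be told apart here, and ethyl alone stands out among the three. No evidence here explains the difference.

Left open is whether propyl at this place reads closer to compound 2 or to compound 3, and how a chain ending in an amine would read.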